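A few compounds are considered here, and "the series" means these few. Any claim that something is new, unique, unknown or untested is made for them only; others in the source may bear on it.

Measured so far:

Compound 1 `COc1cc(/C=C2\CN(C)C/C(=C\c3ccc(Cl)cc3)C2=O)cc(OC)c1OC` gives a limit in this assay, > 20000 nM.

Compound 2 `COc1cc(/C=C2\CN(C)C/C(=C\c3ccc(Br)cc3)C2=O)cc(OC)c1OC` gives 12400 nM.

Compound 3 `CN1C/C(=C\c2ccc(Cl)cc2)C(=O)/C(=C/c2ccc(C#N)cc2)C1` gives 13300 nM.

All three were tested in a functional assay on K562 cells (Homo sapiens) for cytotoxicity, read by MTT assay, with a stated time of 24 h; on this read-out higher numbers stand for weaker inhibition and lower numbers for stronger inhibition. For compound 1 the value is only a limit of the assay, not a number, as noted in the limit of > 20000 nM in this assay, at which 1 of the 3 values shown sits. Compound 2 differs from compound 1 in one place, (bromo in place of chloro on an aromatic carbon), and the change gave an at least 1.6-fold lower number from compound 1 to compound 2 (0.20 log units; that floor lies within the scatter); since the starting point is a limit, the true size of that step is not known. Compound 3 shares a core with compound 1, but how the two cores differ is not broken down here. The values of compound 2 and compound 3 lie within the usual scatter of each other.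

Compound 4 `CN1C/C(=C\c2ccc(Br)cc2)C(=O)/C(=C/c2ccc(C#N)cc2)C1` has not been measured. It differs from compound 3 by bromo in place of chloro on an aromatic carbon, the same change that turns compound 1 into compound 2, at the same kind of position. Because the earlier step reads as an at least 1.6-fold lower number from compound 1 to compound 2 (0.20 log units; that floor lies within the scatter) and rests on a limit, only a small shift in the same direction is expected here: the step from compound 3 to compound 4 is estimated as a 1.4-fold lower number from compound 3 to compound 4 (0.15 log units; within the scatter). Compound 4 is therefore expected to give about 9500 nM in this assay, most likely between 4500 nM and 20000 nM.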

Compound 4, half-maximal inhibitory concentration: 7420 nM
Compound 4: middle estimate off by 1.3-fold (0.11 log units), on the high side; measured number inside the range.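

In this assay, bromo in place of chloro on the core of compound 3 gives a 1.8-fold lower number from compound 3 to compound 4 (0.25 log units; within the scatter), which points the same way as the earlier step on the core of compound 1, but it lies within the usual scatter and cannot by itself be called a real gain. Set side by side, the two steps agree in direction, and this is as far as the comparison goes, with no sign that the swap does anything beyond the scatter on either core: the same change on two cores in this assay, an at least 1.6-fold lower number (0.20 log units; that floor lies within the scatter) from compound 1 to compound 2 and a 1.8-fold lower number (0.25 log units; within the scatter) from compound 3 to compound 4; the limit leaves it open whether they differ. A fixed size for the change, carried from one core to the other, is not shown, since compound 1 gives only a limit and not a number: the limit of > 20000 nM in this assay, at which 1 of the 4 values shown sits.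

The compounds shown carry only chloro or bromo at this place on the ring, so it stays open what fluoro, iodo or an amine there would do in this assay. Also open, from the compounds shown here alone, is whether the step would look the same with a carboxylic acid in place of the nitrile, or with a longer chain on the nitrogen of the shared core.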